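The compounds below may be only part of what the source reports. "The series", "measured", "known", "first", "only" and "open" are said of these compounds alone.

Measured compounds:
- compound 1 `CC(=O)c1cnc(N2CCC(c3coc4c(N5CCc6cc(S(C)(=O)=O)ccc65)ncnc34)CC2)nc1`: 12%
- compound 2 `CC(C)(C)OC(=O)N1CCC(c2noc3c(Nc4ccc(S(C)(=O)=O)cc4F)ncnc23)CC1`: 137%

In a functional assay on cells for agonist activity at Glucose-dependent insulinotropic receptor (Homo sapiens), read by a luciferase reporter, with a stated time of 4 h (on this read-out lower numbers stand for smaller maximal responses and higher numbers for larger maximal responses), compound 1 gives 12%, the lower of the two numbers; compound 2 gives 137%, a gap beyond the usual scatter. Compound 3 `COc1cnc(N2CCC(c3coc4c(N5CCc6cc(S(C)(=O)=O)ccc65)ncnc34)CC2)nc1` keeps the core of compound 1 and differs by methoxy in place of acetyl on an aromatic carbon. Going by the values given here, no measured pair shows this change, so the direction in this assay is open; a modest step, either way or none beyond the scatter, is expected. Compound 3 is estimated at 20%, range 5% to 60%, which means an expected step of a number 8 percentage points higher from compound 1 to compound 3 (within the scatter).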

Compound 3, largest response reached (Emax), in percent of the reference or control that the assay uses: 186%
Compound 3: middle estimate off by 166 percentage points, on the low side, outside the stated range (above it).
By their numbers in this assay, from the lowest: compound 1; then compound 2; then compound 3.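

In this assay, going from 5-acetylpyrimidin-2-yl to 5-methoxypyrimidin-2-yl gives a number 174 percentage points higher from compound 1 to compound 3 (beyond the scatter) on an otherwise unchanged structure. This one aromatic carbon, para to a large group, therefore separates a small maximal response from a large one, and the rest of compound 1 does not by itself fix the low response. No available measurement explains the size of this step.

On these data alone, whether acetyl suppresses the response or methoxy raises it remains open. An amine, a chlorine atom or an ethoxy group at this carbon would help separate the two readings.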